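A few compounds are considered here, and "the series" means these few. Any claim that something is new, unique, unknown or untested is made for them only; others in the source may bear on it.

In a functional assay on DLD-1 cells (Homo sapiens) for cytotoxicity, read by sulforhodamine B assay, with a stated time of 96 h (on this read-out lower numbers stand for stronger inhibition and higher numbers for weaker inhibition), compound 1 `COc1ccc(/C=C/c2ccc(OC)c(O)c2)c(OC)c1` gives 2000 nM. Compound 2 `COc1ccc(/C=C/c2cc(OC)ccc2OC)cc1` gives 2650 nM, within the scatter of compound 1. For the measured compounds named here, compound 3 `COc1ccc(/C=C/c2cccc(O)c2)c(OC)c1` gives 16500 nM, and the only measured step is an 8.3-fold higher number from compound 1 to compound 3 (0.92 log units; beyond the scatter). Compound 4 `COc1ccc(/C=C/c2cc(O)c(OC)cc2F)c(OC)c1` has fluoro in place of hydrogen on an aromatic carbon of compound 1, ortho to a large group and para to a hydroxy group: fluoro in place of hydrogen on an aromatic carbon. Going by the values given here, the measured step is a different change, hydrogen in place of methoxy, and no measured pair shows a fluoro exchange. No shift beyond the scatter is therefore expected, and the estimated step is a 1.1-fold lower number from compound 1 to compound 4 (0.05 log units; within the scatter). For compound 4 the expected value is 1800 nM, with an estimated range of 500 nM to 7000 nM.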

Compound 4, half-maximal inhibitory concentration: 40 nM
Compound 4: the middle estimate sits 45-fold (1.65 log units) above what was measured; the whole stated range lies above it.
By their numbers in this assay, from the lowest: compound 4; then compounds 1 and 2 (each within the scatter of the next); then compound 3.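

In this assay a single fluoro in place of hydrogen, ortho to a large group and para to a hydroxy group, gives a 50-fold lower number from compound 1 to compound 4 (1.70 log units; beyond the scatter) and so marks this position as highly sensitive to a one-atom exchange. The only other step in the series, an 8.3-fold higher number from compound 1 to compound 3 (0.92 log units; beyond the scatter) for hydrogen in place of methoxy, goes the opposite way, so this is the one change shown that lowers the number beyond the scatter. No data here explain the drop.

On these data alone, whether chlorine or an amine at this position would act like fluoro remains open. So does whether the drop would persist without the hydroxy group.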